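This account rests on a few compounds, and the source may have more. Where it says the series, first, only, none or still open, it means among the compounds named here.

Of the compounds shown here, two sharing one core have been measured so far. Compound 1 `COc1cc(NC(C)CCCNC(=O)NCCNC(c2ccccc2)(c2ccccc2)c2ccccc2)c2ncccc2c1` carries a trityl-bearing tail, while compound 2 `COc1cc(NC(C)CCCNC(=O)NNC(=O)N(CCO)CCO)c2ncccc2c1` carries a urea-linked tail ending in the bis(2-hydroxyethyl)amino group. In a functional assay on MCF7 cells (Homo sapiens) for inhibition, read by MTT assay, with a stated time of 4 days (a higher number here means a weaker inhibitor, a lower number a stronger inhibitor), compound 1 gives 45000 nM and compound 2 gives 29000 nM. These two numbers lie within the usual scatter of one another, so neither compound can be called the stronger inhibitor on this evidence; both are weak.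

Compound 3 `COc1cc(NC(C)CCCNC(=O)NNC(=O)NC(CO)(CO)CO)c2ncccc2c1` is the next compound to be measured. It differs from compound 2 in one place: (2-hydroxy-1,1-bis(hydroxymethyl)ethyl)amino in place of bis(2-hydroxyethyl)amino on a carbonyl carbon. The change swaps one small, uncharged, hydroxyl-rich group for another of closely similar size, with the counts of donors and acceptors rising slightly.

Going by the values given here, no measured step of this kind is available for comparison. The expectation for compound 3 in this assay is that the step of a 1.0-fold higher number from compound 2 to compound 3 (0.01 log units; within the scatter) stays within the scatter, neither clearly stronger nor weaker. The value of compound 3 is therefore estimated at 30000 nM, with a likely range from 12000 nM to 80000 nM.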

Compound 3, half-maximal inhibitory concentration: 28000 nM
Compound 3: the middle estimate sits 1.1-fold (0.03 log units) above what was measured, within the range that was stated.
By their numbers in this assay, from the lowest: compounds 3, 2 and 1 (each within the scatter of the next).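

Going by these compounds alone, this is the first comparison here in which only one place differs, and in this assay the swap of bis(2-hydroxyethyl)amino for (2-hydroxy-1,1-bis(hydroxymethyl)ethyl)amino on a carbonyl carbon gives a 1.0-fold lower number from compound 2 to compound 3 (0.02 log units; within the scatter). The entering group has one more oxygen and higher counts of hydrogen-bond donors and acceptors, yet the two compounds cannot be told apart in this assay, so at this place the difference in those counts leaves no readable mark on the number. Nothing available explains why the values stay so close, so this result records only an outcome and gives no mechanism.

Both groups compared here are uncharged, ring-free and hydroxyl-bearing, so this step says little about how a group of another kind would behave on the same carbonyl carbon. As far as these compounds go, it remains open whether a simple amine, a carboxylic acid or a longer alkyl chain at this place would move the number beyond the scatter, or whether the reading in this assay barely depends on what sits there.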